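Anilino swap on the thiazolopyrimidine core: chloro to methylsulfanyl

The source may report more compounds than this note shows. Statements on the series, on what has been measured and on what is new or still open speak of the compounds shown alone.

Of the compounds shown here, two sharing one core have been measured in a functional assay on HEK293 cells for antagonist activity at transient receptor potential cation channel subfamily V member 1 (Homo sapiens), read by calcium flux; on this read-out lower numbers stand for stronger inhibition and higher numbers for weaker inhibition. Compound 1 `Cc1cccc(C)c1Nc1nc2c(Nc3ccc(C(F)(F)F)cc3)ncnc2s1` gives 23 nM in this assay. Compound 2 `FC(F)(F)c1ccc(Nc2ncnc3sc(Nc4ccccc4Cl)nc23)cc1` gives 64 nM, and it stands highest of the two numbers, its nearest neighbour being compound 1 at a 2.8-fold higher number from compound 1 to compound 2 (0.44 log units; beyond the scatter). Within the data shown here, that step, 2-chlorophenyl in place of 2,6-dimethylphenyl on a nitrogen on an aromatic ring, is the only measured step available.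

Compound 3 `CSc1ccccc1Nc1nc2c(Nc3ccc(C(F)(F)F)cc3)ncnc2s1` has not been measured. It differs from compound 2 by methylsulfanyl in place of chloro on an aromatic carbon, the full change reading 2-chlorophenyl to 2-(methylsulfanyl)phenyl. Among the measured compounds shown here, no measured step exchanges the group on this aromatic carbon directly; the step from compound 1 to compound 2 bears on it only loosely, since it shows that the group on this ring moves the number by a modest amount in either direction.

Compound 3 is therefore expected to sit close to compound 2, with the step of a 1.6-fold lower number from compound 2 to compound 3 (0.20 log units; within the scatter) estimated as modest at most, probably toward a lower number. The estimate for compound 3 is 40 nM, expected within 15 nM to 110 nM.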

Compound 3, half-maximal inhibitory concentration: 43 nM
Compound 3: the middle estimate sits 1.1-fold (0.03 log units) below what was measured; the range from low to high includes it.
By their numbers in this assay, from the lowest: compounds 1, 3 and 2 (each within the scatter of the next, the first and the last beyond it).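

In this assay, methylsulfanyl in place of chloro on this aromatic carbon gives a 1.5-fold lower number from compound 2 to compound 3 (0.17 log units; within the scatter), so the read-out does not separate the two groups, even though 2 heavy atoms enter where 1 heavy atom leaves and 1 hydrogen-bond acceptor comes in. Set against the 2,6-dimethylphenyl group, 2-(methylsulfanyl)phenyl gives a 1.9-fold higher number from compound 1 to compound 3 (0.27 log units; within the scatter), whereas 2-chlorophenyl gave a 2.8-fold higher number from compound 1 to compound 2 (0.44 log units; beyond the scatter); compound 3 therefore lies within the scatter of two compounds that lie beyond the scatter of each other, and this position accepts a sulfur-bearing group with no readable loss. Nothing here accounts for these numbers in terms of any measured property of the groups.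

On these data alone, it remains open whether a methoxy, a nitrile or an aminomethyl group on this same aromatic carbon would also stay within the scatter of compound 3. As far as these compounds go, it is equally open whether these close numbers would hold if the trifluoromethyl on the other aromatic ring gave way to a carboxylic acid.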